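The source may report more compounds than this note shows. Statements on the series, on what has been measured and on what is new or still open speak of the compounds shown alone.

The series begins with compound 1 `NS(=O)(=O)c1ccc(/N=C/c2c(Cl)c3ccccc3oc2=O)cc1`, which in a functional assay on MCF7 cells (Homo sapiens) for cytotoxicity, read by CCK-8 assay, with a stated time of 48 h (on this read-out lower numbers stand for stronger inhibition and higher numbers for weaker inhibition), gives 120 nM. Compound 2 `CC(C)(C)c1cc(C(C)(C)C)c2oc(=O)c(/C=N/c3ccc(S(=O)(=O)Nc4nccs4)cc3)c(Cl)c2c1`, carrying two tert-butyl groups on the shared core and a 1,3-thiazol-2-yl group on the sulfonamide nitrogen, gives 12 nM in this assay. For the measured compounds named here, compound 3 `Cc1cc(C)nc(NS(=O)(=O)c2ccc(/N=C/c3c(Cl)c4cc(C(C)(C)C)cc(C(C)(C)C)c4oc3=O)cc2)n1` gives 8.8 nM in this assay, and the only measured single-point step, a 1.4-fold lower number from compound 2 to compound 3 (0.13 log units; within the scatter), lies within the scatter. Compound 3 thus sits at the low end of the three numbers, separated from compound 1 by a gap beyond the scatter but not separated from compound 2.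

Compound 4 `Cc1ccnc(NS(=O)(=O)c2ccc(/N=C/c3c(Cl)c4cc(C(C)(C)C)cc(C(C)(C)C)c4oc3=O)cc2)n1` differs from compound 3 by hydrogen in place of methyl on an aromatic carbon. Going by the values given here, the one measured step bears on it only loosely: it swapped the whole heterocycle on the sulfonamide nitrogen and moved the number within the scatter, whereas no measured step removes a single methyl from that heterocycle. A change this small is therefore expected to give no step beyond the scatter in this assay, in either direction. The expected step is a 1.1-fold higher number from compound 3 to compound 4 (0.06 log units; within the scatter). The estimate for compound 4 in this assay is 10 nM, expected to fall between 4 nM and 25 nM.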

Compound 4, half-maximal inhibitory concentration: 32 nM
Beside the measured number, compound 4's estimate is 3.2-fold (0.51 log units) below it, and the stated range ends below it.
By their numbers in this assay, from the lowest: compounds 3 and 2 (each within the scatter of the next); then compound 4; then compound 1.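

Going from 4,6-dimethylpyrimidin-2-yl to 4-methylpyrimidin-2-yl on the sulfonamide nitrogen gives, in this assay, a 3.6-fold higher number from compound 3 to compound 4 (0.56 log units; beyond the scatter), so a single methyl on this aromatic carbon counts for more than the scatter, which the earlier single-place step did not reach. Exchanging the heterocycle on the sulfonamide nitrogen also gives a step beyond the scatter when the group entering is 4-methylpyrimidin-2-yl, with a 2.7-fold higher number from compound 2 to compound 4 (0.43 log units; beyond the scatter), so the outcome of such a swap depends on the methyl groups the entering ring carries. No measurement at hand gives a reason for either step.

The compounds shown leave open what the remaining methyl contributes, and how a ring with no methyl at all would compare. They also leave open whether an ethyl, a methoxy or an amine at this place would behave as the methyl does.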